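The source may report more compounds than this note shows. Statements on the series, on what has been measured and on what is new or still open speak of the compounds shown alone.

Working notes on the series.

Within the data shown here, compound 1 `CCc1nc2ccccc2n1CCCCOc1ccccc1` is the only member of the series with a number in an ADME assay on Vero cells (Chlorocebus sabaeus) for cytotoxicity, read by luminescence, with a stated time of 2 days; on this read-out higher numbers stand for lower toxicity in this test and lower numbers for higher toxicity in this test. In this assay compound 1 gives 21 uM. Compound 2 `Clc1nc2ccccc2n1CCCCOc1ccccc1` shares the same core, and in this assay compound 2 is recorded as "not determined" (no result reported), so no number can be set beside it. Among the measured compounds shown here, no pair of measured compounds differs in a single place, and no measured step is available to size a change of this kind.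

Compound 3 `CCc1nc2ccccc2n1CCCCOc1cccnc1` is the next entry and has not been measured. It differs from compound 1 in one place: pyridin-3-yl in place of phenyl on an oxygen on a saturated carbon. The oxygen on the saturated carbon and the chain between it and the core are unchanged.

With only the value of compound 1 to go on, the step from compound 1 to compound 3 is expected to be small in this assay, and is estimated as a 1.2-fold higher number from compound 1 to compound 3 (0.08 log units; within the scatter), not clearly beyond the usual scatter in either direction. Compound 3 is accordingly expected to give about 25 uM in this assay, with the estimate spanning 10 uM to 60 uM.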

Compound 3, half-maximal toxic concentration: > 50 uM
Compound 3: no number, only a limit (the forecaster's own chance of this, stated with the estimate: 15%); at least 2.0-fold (0.30 log units) between middle value and limit.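

In this assay, among these compounds, the change on the oxygen on a saturated carbon now has a measured direction, and pyridin-3-yl in place of phenyl gives an at least 2.3-fold higher number from compound 1 to compound 3 (0.37 log units; beyond the scatter), the first step that can be read and one that lies beyond the scatter. On this read-out the change points towards lower toxicity in this test, so this position is not silent to a change that leaves the heavy-atom count alone and swaps one ring carbon for a nitrogen. Compound 3 gives > 50 uM in this assay, which is a limit and not a number, so the step has a floor but no upper end, and its full size stays unknown: the limit of > 50 uM in this assay, at which 1 of the 3 values shown sits.

Left open is whether pyridin-4-yl, or a phenyl carrying an amine or a carboxylic acid, would move the number the same way at this place, and whether a longer chain between the oxygen and the core would alter the step. The compounds shown also give no way to tell whether the change carries over to the core of compound 2, which has no result to compare.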